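This account rests on a few compounds, and the source may have more. Where it says the series, first, only, none or still open, it means among the compounds named here.

Measured compounds:
- compound 1, `CN(/N=N/c1ccc(C#N)cc1)C(=O)CCc1ccc(O)cc1`: 2.99 h
- compound 3, `CC(=O)c1ccc(/N=N/N(C)C(=O)CCc2ccc(O)cc2)cc1`: 4.9 h
- compound 2, `CCOC(=O)c1ccc(/N=N/N(C)C(=O)NCCSc2ccc(O)cc2)cc1`: 30.5 h

In an ADME assay on a cell-free system (plasma, Homo sapiens) for metabolic stability, read by HPLC (a higher number here means that the compound lasts longer, a lower number that the compound disappears faster), compound 1 stands lowest of the three numbers; compound 3 is nearest, and compound 2 lies furthest off. Compound 4, `CCOC(=O)c1ccc(/N=N/N(C)C(=O)CCc2ccc(O)cc2)cc1`, differs from compound 1 by ethoxycarbonyl in place of cyano on an aromatic carbon. For the measured compounds named here, the only step that bears on this change is a 1.6-fold higher number from compound 1 to compound 3 (0.21 log units; within the scatter), where a different group also replaced the cyano at the same place. Compound 2 carries the ethoxycarbonyl but differs elsewhere as well, so its higher value cannot be assigned to that group alone. Compound 4 is therefore expected to move a 1.7-fold higher number from compound 1 to compound 4 (0.22 log units; within the scatter), a shift that may not exceed the scatter. The estimate for compound 4 is 5 h, with a range of 2.5 h to 11 h.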

Compound 4, half-life in the Homo sapiens assay: 6.57 h
Beside the measured number, compound 4's estimate is 1.3-fold (0.12 log units) below it; the measured number falls inside the stated range.
By their numbers in the Homo sapiens assay, from the lowest: compounds 1, 3 and 4 (each within the scatter of the next, the first and the last beyond it); then compound 2.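

In the Homo sapiens assay, compound 1 gives 2.99 h and compound 4 gives 6.57 h. In the Homo sapiens assay, ethoxycarbonyl in place of cyano gives a 2.2-fold higher number from compound 1 to compound 4 (0.34 log units; beyond the scatter). Yet in the Homo sapiens assay, ethoxy in place of methyl on the carbonyl carbon gives a 1.3-fold higher number from compound 3 to compound 4 (0.13 log units; within the scatter), so the acetyl and ethoxycarbonyl groups cannot be told apart. In a physicochemical assay for pharmacokinetics, read by HPLC, in phosphate buffer, at pH 7.4 (on this read-out lower numbers stand for a shorter-lived compound and higher numbers for a longer-lived compound), compound 1 gives 86.4 h and compound 4 gives 130 h. In the physicochemical assay, the cyano change gives a 1.5-fold higher number from compound 1 to compound 4 (0.18 log units; within the scatter), which stays within the scatter. Nothing shown accounts for the step away from cyano. As far as these compounds go, whether an amine or a carboxylic acid at this place would give a similar half-life remains open.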